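The source may hold more compounds than are shown below. What is called first, only, known or untested is meant among the compounds shown, and "the series" means these compounds.

Measured compounds in an assay on a protein complex for inhibition of NEDD8 activating enzyme (Homo sapiens), read by HTRF, with a stated time of 2 h, in the presence of a further agent that is not named here; a lower number here means a stronger inhibitor, a higher number a weaker inhibitor:

compound 1, `NS(=O)(=O)OC[C@@H]1C[C@@H](n2nnc3c(N[C@H]4CCc5ccccc54)ncnc32)C[C@@H]1O`: 0.21 nM
compound 2, `NS(=O)(=O)OC[C@@H]1C[C@@H](n2ncc3c(N[C@H]4CCc5ccccc54)ccnc32)C[C@@H]1O`: > 10000 nM
compound 3, `CCCCCCNc1ncnc2c1nnn2[C@@H]1C[C@@H](COS(N)(=O)=O)[C@@H](O)C1`; in this assay compound 3 gives 21.1 nM.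

The figure of compound 2 is a limit of this assay, not a number, as set out in the limit of > 10000 nM in this assay, at which 1 of the 3 values shown sits. Among the two numbers that are measured, compound 3 stands at the higher end; its nearest neighbour is compound 1, and the step of a 100-fold higher number from compound 1 to compound 3 (2.00 log units; beyond the scatter) is large and well beyond the scatter.

Compound 4, `NS(=O)(=O)OC[C@@H]1C[C@@H](n2nnc3c(Nc4cnc5ccccn45)ncnc32)C[C@@H]1O`, is not yet measured in this assay. It differs from compound 3 by a group of 9 heavy atoms (7 carbon, 2 nitrogen; one five-membered aromatic ring with 2 hetero atoms, one six-membered aromatic ring with 1 hetero atom) in place of a group of 6 heavy atoms (6 carbon; no ring), on a nitrogen on an aromatic ring. Going by the values given here, the one measured step that bears on this change is a 100-fold higher number from compound 1 to compound 3 (2.00 log units; beyond the scatter), where a fused bicyclic ring at this nitrogen gave a far lower number than the open hexyl chain. Compound 4 carries a fused bicyclic group again, though fully aromatic with two nitrogens rather than the partly saturated ring of compound 1, so a step toward lower numbers is expected, most likely smaller than the measured one: a 7.0-fold lower number from compound 3 to compound 4 (0.85 log units; beyond the scatter). Compound 4 is therefore estimated at 3 nM, with a range from 0.4 nM to 25 nM.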

Compound 4, half-maximal inhibitory concentration: > 10000 nM
Compound 4: only a limit was reported; the forecaster's own chance of this, stated with the estimate: 2%; middle value at least 3300-fold (3.52 log units) away from the limit.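

In this assay compound 4 gives > 10000 nM, which is a limit of the assay and not a number: the limit of > 10000 nM in this assay, at which 2 of the 4 values shown sit. Even so, the direction at this nitrogen can be read: the step against the open chain is an at least 470-fold higher number from compound 3 to compound 4 (2.67 log units; beyond the scatter), and the step against the partly saturated group is an at least 47000-fold higher number from compound 1 to compound 4 (4.67 log units; beyond the scatter). A fused two-ring group on this nitrogen therefore does not by itself give a low number, since hexyl lies between the two fused groups, both of 9 heavy atoms.

The compounds shown leave open whether the loss goes with the ring nitrogens, with full aromaticity or with attachment through an aromatic carbon, as these change together in one step. A phenyl, a benzyl or a cyclohexyl on this nitrogen would begin to separate them.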